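Removing one methoxy from the aryl ketone ring

The compounds below may be only part of what the source reports. "The series", "measured", "known", "first", "only" and "open" are said of these compounds alone.

Measured compounds:
- Compound 1, `COc1cc(-c2cc(/C=C/C(=O)c3ccc(N)cc3)[nH]n2)cc(OC)c1OC`: 103%
- Compound 2, `COc1cc(-c2cc(/C=C/C(=O)c3ccc(Cl)c(Cl)c3)[nH]n2)cc(OC)c1OC`: 92%
- Compound 3, `COc1ccc(C(=O)/C=C/c2cc(-c3cc(OC)c(OC)c(OC)c3)n[nH]2)cc1OC`: 101%

In a functional assay on NCI-H322M cells (Homo sapiens) for cytotoxicity, read by sulforhodamine B assay, with a stated time of 48 h, tested at 0.1 uM (a lower number here means a stronger effect, a higher number a weaker effect of the compound at the concentration tested), compound 3 gives 101%. Among the three measured numbers, compound 3 stands second highest; its nearest neighbour is compound 1, and the difference between them is within the scatter, a number 2 percentage points lower from compound 1 to compound 3 (within the scatter). Its furthest neighbour is compound 2, and that gap too is within the scatter, a number 9 percentage points higher from compound 2 to compound 3 (within the scatter). Within the data shown here, the only step beyond the scatter is the one between compound 1 and compound 2, a number 11 percentage points lower from compound 1 to compound 2 (beyond the scatter), which is modest.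

Compound 4, `COc1ccc(C(=O)/C=C/c2cc(-c3cc(OC)c(OC)c(OC)c3)n[nH]2)cc1`, has not yet been measured. It differs from compound 3 in one place: hydrogen in place of methoxy on an aromatic carbon.

Among the measured compounds shown here, the steps that bear on this change are those in which the substituent pattern on the carbonyl-bearing ring was varied. Going from compound 1 to compound 3, and from compound 2 to compound 3, the changes stayed within the scatter. All three measured compounds sit close to the level meaning no effect at the concentration tested. A step from compound 3 to compound 4 of a number 1 percentage points lower from compound 3 to compound 4 (within the scatter) is therefore expected, that is none beyond the scatter. For compound 4 in this assay the expected value is 100%, with a range from 88% to 112%.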

Compound 4, a percentage reported as activity, at one concentration (the size of the read-out at that concentration, not a potency): 96%
Beside the measured number, compound 4's estimate is 4 percentage points above it; low and high end bracket the measured number.
By their numbers in this assay, from the lowest: compounds 2, 4, 3 and 1 (each within the scatter of the next, the first and the last beyond it).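

In this assay the loss of one methoxy, taking the 3,4-dimethoxyphenyl ring to the 4-methoxyphenyl ring, gives a step that stays within the scatter (a number 5 percentage points lower from compound 3 to compound 4 (within the scatter)), so this aromatic carbon, ortho to a methoxy group, shows no measurable dependence on methoxy over hydrogen at the concentration tested. The earlier steps shown here exchanged the whole aryl ketone ring, whereas this one alters a single group on it, and compound 4 also cannot be told apart from the rings carrying other substituents (a number 4 percentage points higher from compound 2 to compound 4 (within the scatter); a number 7 percentage points lower from compound 1 to compound 4 (within the scatter)). No measurement at hand accounts for these numbers, whether a property of the methoxy group or anything else.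

On these data alone, all of this rests on one low concentration with the numbers close to the level meaning no effect, so whether the methoxy counts at concentrations where the compounds do act remains open. Also open, as far as these compounds go, is whether a hydroxy group, an amine or a longer chain such as ethoxy on this aromatic carbon would read differently from hydrogen and methoxy.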